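From pyrrolidine to piperidine on the sulfonyl sulfur

This account rests on a few compounds, and the source may have more. Where it says the series, first, only, none or still open, it means among the compounds named here.

Compound 1 `COC(=O)NC(=O)c1ccsc1NC(=O)c1ccc(S(=O)(=O)N2CCC(OC)CC2)cc1`: 46.1 ug/mL
Compound 2 `CCOC(=O)NC(=O)c1ccsc1NC(=O)c1ccc(S(=O)(=O)N2CCCC2)cc1`: 62.9 ug/mL

Both values come from a toxicity assay on HepG2 cells (Homo sapiens) for cytotoxicity, read by MTT assay; a higher number here means a weaker inhibitor, a lower number a stronger inhibitor. In this assay, compound 2 stands at 62.9 ug/mL and compound 1 stands at 46.1 ug/mL, so the two compounds lie within the scatter of each other and cannot be ranked. Compound 3 `CCOC(=O)NC(=O)c1ccsc1NC(=O)c1ccc(S(=O)(=O)N2CCCCC2)cc1` has not yet been measured. It has piperidin-1-yl in place of the pyrrolidin-1-yl of compound 2 on a sulfonyl sulfur: piperidin-1-yl in place of pyrrolidin-1-yl on a sulfonyl sulfur. The rest of the structure stays the same. Within the data shown here, no pair of measured compounds differs in only one place, so the data offer no direct precedent for this change. The expectation therefore rests on the narrow spread of the two known values, with compound 2 at 62.9 ug/mL as its starting point. No change beyond the scatter is expected in this assay, and no direction can be favoured with any confidence. The estimate amounts to a step of a 1.1-fold lower number from compound 2 to compound 3 (0.06 log units; within the scatter), which is expected to stay within the usual scatter. Compound 3 is expected to give 55 ug/mL, with an estimated range of 28 ug/mL to 105 ug/mL.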

Compound 3, half-maximal inhibitory concentration: 38.8 ug/mL
Compound 3: the middle estimate sits 1.4-fold (0.15 log units) above what was measured, within the range that was stated.
By their numbers in this assay, from the lowest: compounds 3, 1 and 2 (each within the scatter of the next).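

Among these compounds, the exchange of pyrrolidin-1-yl for piperidin-1-yl on a sulfonyl sulfur gives the first comparison in this set that differs in only one place: in this assay, the change is a 1.6-fold lower number from compound 2 to compound 3 (0.21 log units; within the scatter). This step lies within the scatter, so compound 2 and compound 3 cannot be ranked, and this pair gives no sign that going from the five-membered to the six-membered ring, with the rest of the structure unchanged, shifts the read-out in this assay. No accompanying measurement bears on what lies behind these numbers.

One pair cannot show whether this position responds little to amine rings in general, or whether the result is specific to these two rings. Going by these compounds, it remains open whether morpholin-4-yl, azepan-1-yl or an open-chain diethylamino group on the same sulfonyl sulfur would also stay within the scatter of compound 2, and whether the same exchange would read the same way with a different group at the other end of the molecule.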